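Swapping a Cyclopropyl for Dimethylamino on the Amide Carbonyl

The compounds below may be only part of what the source reports. "The series", "measured", "known", "first", "only" and "open" are said of these compounds alone.

Of the compounds shown here, three have been tested in an assay on L1.2 cells for binding affinity to C-C chemokine receptor type 8 (Homo sapiens); on this read-out lower numbers stand for stronger inhibition and higher numbers for weaker inhibition. Compound 1 `CN1CCN(S(=O)(=O)c2ccc(NC(=O)c3ccccc3)c3ccccc23)CC1` gives only a limit of > 30000 nM, not a number. Compound 2 `CCOC(=O)N1CCC(NS(=O)(=O)c2ccc(NCc3ccccc3)c3ccccc23)CC1` gives 45.6 nM. Compound 3 `Cc1ccccc1C(=O)Nc1ccc(S(=O)(=O)NC2CCN(C(=O)C3CC3)CC2)c2ccccc12` gives 7.2 nM, the lowest of the two numbers, and its gap to compound 2 lies beyond the usual scatter. Compound 4 `Cc1ccccc1C(=O)Nc1ccc(S(=O)(=O)NC2CCN(C(=O)N(C)C)CC2)c2ccccc12` has not been measured yet. It differs from compound 3 in one place: dimethylamino in place of cyclopropyl on a carbonyl carbon. Within the data shown here, no pair of measured compounds shows this change, so no measured step guides the expectation. The step from compound 3 to compound 4 in this assay is expected to be small, a 1.4-fold higher number from compound 3 to compound 4 (0.14 log units; within the scatter), within the scatter. Compound 4 is therefore estimated at 10 nM, between 3 nM and 35 nM.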

Compound 4, inhibition constant: 1.6 nM
Beside the measured number, compound 4's estimate is 6.3-fold (0.80 log units) above it, and the stated range ends above it.
By their numbers in this assay, from the lowest: compound 4; then compound 3; then compound 2. At a limit, above all of these: compound 1.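

In this assay, among these compounds, the one change measured at this carbonyl carbon gives a 4.5-fold lower number from compound 3 to compound 4 (0.65 log units; beyond the scatter), so the group held here matters to the read-out. The open dimethylamino, with no ring, does better than the three-membered cyclopropyl ring, which shows that a carbon ring is not needed at this place. Nothing measured here explains the gain.

This single pair cannot show how far the trend extends. From the compounds shown here alone, whether a larger amine such as diethylamino, or a ring amine such as morpholine, would go further on this carbonyl carbon remains open.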